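Does a Chlorine Bring Compound 4 Into Range?

A few compounds are considered here, and "the series" means these few. Any claim that something is new, unique, unknown or untested is made for them only; others in the source may bear on it.

Four compounds share one core and differ on its aromatic ring. Compound 1 `CCN1CCCC1CNC(=O)c1cc(NS(=O)(=O)N(C)C)c(Cl)cc1OC` gives 8.3 mg/kg in a functional assay on the whole organism for inhibition, with Mus musculus as the target (a lower number here means that less compound is needed, a higher number that more compound is needed for the effect), and compound 2 `CCN1CCCC1CNC(=O)c1cc(NS(C)(=O)=O)c(Cl)cc1OC` gives 9.1 mg/kg. The step of a 1.1-fold higher number from compound 1 to compound 2 (0.04 log units; within the scatter) shows that exchanging the group on the sulfonyl sulfur changes little. Compound 3 `CCN1CCCC1CNC(=O)c1cc(N(C)S(N)(=O)=O)ccc1OC` reaches only the limit > 50 mg/kg in this assay. It is among the values at the limit of > 50 mg/kg in this assay, at which 1 of the 3 values shown sits. Compound 4 `CCN1CCCC1CNC(=O)c1cc(N(C)S(N)(=O)=O)c(Cl)cc1OC` differs from compound 3 by chloro in place of hydrogen on an aromatic carbon. Among the compounds with values here, no measured step covers this chlorine, but both chlorine-bearing compounds gave measurable numbers while compound 3 did not, which is the only basis for an expectation. Compound 4 is therefore estimated at 20 mg/kg, between 7 mg/kg and 60 mg/kg. For compound 4 this expectation means a step of an at least 2.5-fold lower number from compound 3 to compound 4 (0.39 log units; beyond the scatter), with wide uncertainty.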

Compound 4, dose for half-maximal effect: > 50 mg/kg
Compound 4: only a limit was reported (the forecaster's own chance of this, stated with the estimate: 35%); middle value at least 2.5-fold (0.39 log units) away from the limit.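

Chloro in place of hydrogen on this aromatic carbon does not by itself bring a methyl(sulfamoyl)amino compound into measurable range, and the step between the two limits for compound 3 and compound 4 cannot be read. With the chlorine kept, the sulfonyl-bearing group matters: methyl(sulfamoyl)amino in place of methanesulfonamido gives an at least 5.4-fold higher number from compound 2 to compound 4 (0.73 log units; beyond the scatter), and in place of (dimethylsulfamoyl)amino it gives an at least 6.0-fold higher number from compound 1 to compound 4 (0.77 log units; beyond the scatter). Compound 3 and compound 4 both end at a limit, not a number: the limit of > 50 mg/kg in this assay, at which 2 of the 4 values shown sit.

Within the data shown here, no pair with two readable numbers isolates the chlorine, so its effect remains open. From the compounds shown here alone, how a fluorine atom or a methyl group on that carbon would behave also remains open.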